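The source may hold more compounds than are shown below. What is called first, only, known or untested is meant among the compounds shown, and "the series" means these compounds.

Measured so far in an assay on HEK293 cells for displacement of a labelled ligand from prostaglandin D2 receptor 2 (Homo sapiens); a lower number here means a stronger inhibitor, a higher number a weaker inhibitor:
compound 1, `O=C(O)Cn1c(SCCCNc2ccccc2)nc2ccccc21`, 2690 nM
compound 2, `CCCCCCSc1nc2ccccc2n1CC(=O)O`, 1360 nM

For the measured compounds named here, compound 2 and compound 1 lie within the scatter of each other in this assay, the only step between them being a 2.0-fold lower number from compound 1 to compound 2 (0.30 log units; within the scatter). Compound 3, `Cc1ccccc1CSc1nc2ccccc2n1CC(=O)O`, is not yet measured. It differs from compound 2 by 2-methylphenyl in place of pentyl on a saturated chain carbon bound to a sulfur. Going by the values given here, the sole measured step bears on it only loosely, changing a chain end further from the sulfur, and it stayed within the scatter. No step beyond the scatter is therefore expected here; the estimate for compound 3 is 1100 nM, range 300 nM to 4000 nM, meaning an expected step of a 1.2-fold lower number from compound 2 to compound 3 (0.09 log units; within the scatter).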

Compound 3, half-maximal inhibitory concentration: 810 nM
Compound 3: middle estimate off by 1.4-fold (0.13 log units), on the high side; low and high end bracket the measured number.
By their numbers in this assay, from the lowest: compounds 3, 2 and 1 (each within the scatter of the next, the first and the last beyond it).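

In this assay, 2-methylphenyl in place of pentyl on a saturated chain carbon bound to a sulfur gives a 1.7-fold lower number from compound 2 to compound 3 (0.23 log units; within the scatter). For the compounds shown here, this carbon therefore carries a six-membered aromatic ring of carbon only with no step beyond the scatter, whereas the earlier compounds held only open chains there. No evidence on the reason for this is at hand.

Open, from the compounds shown here alone, is whether plain phenyl, or a ring bearing chlorine or methoxy instead of methyl, would move the number beyond the scatter.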